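This account rests on a few compounds, and the source may have more. Where it says the series, first, only, none or still open, it means among the compounds named here.

Measured compounds:
compound 1, `CC(C)c1n[nH]c2c(NCc3ccc(-c4ccccn4)cc3)nc(SCC(O)C(F)(F)F)nc12`; in a functional assay on HT cells (Homo sapiens) for antiproliferative activity, read by fluorescence, with a stated time of 72 h (on this read-out higher numbers stand for weaker inhibition of growth and lower numbers for stronger inhibition of growth), compound 1 gives 690 nM
compound 2, `CC(C)c1n[nH]c2c(NCc3ccc(-c4ccccn4)cc3)nc(SCCC(N)=O)nc12`; compound 2 gives 120 nM
compound 3, `CC(C)c1n[nH]c2c(NCc3ccc(-c4ccccn4)cc3)nc(SCCn3ccnc3)nc12`; compound 3 gives 155 nM

Compound 2 has the lowest number of the three; its gap to compound 3 is a 1.3-fold higher number from compound 2 to compound 3 (0.11 log units; within the scatter) and lies within the scatter, while the gap to compound 1 lies beyond it. Compound 4, `CC(C)c1n[nH]c2c(NCc3ccc(-c4ccccn4)cc3)nc(S)nc12`, differs from compound 2 by hydrogen in place of 2-carbamoylethyl on a sulfur. Among the compounds with values here, no measured step removes the chain outright; the steps that bear on it vary the chain end: a 5.8-fold lower number from compound 1 to compound 2 (0.76 log units; beyond the scatter) and a 4.5-fold lower number from compound 1 to compound 3 (0.65 log units; beyond the scatter), both modest. Loss of the whole 2-carbamoylethyl group is a larger change, so a step beyond the scatter toward weaker inhibition is expected: a 5.8-fold higher number from compound 2 to compound 4 (0.77 log units; beyond the scatter). Compound 4 is estimated at 700 nM, between 200 nM and 2500 nM.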

Compound 4, concentration for 50% growth inhibition: 2760 nM
Compound 4: middle estimate off by 3.9-fold (0.60 log units), on the low side; measured number above the stated range.
By their numbers in this assay, from the lowest: compounds 2 and 3 (each within the scatter of the next); then compound 1; then compound 4.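

In this assay, within the data shown here, hydrogen on the sulfur gives the highest number so far, with a 23-fold higher number from compound 2 to compound 4 (1.36 log units; beyond the scatter) and an 18-fold higher number from compound 3 to compound 4 (1.25 log units; beyond the scatter) as large steps and a 4.0-fold higher number from compound 1 to compound 4 (0.60 log units; beyond the scatter) as a modest one. All three chains on the sulfur therefore go with stronger inhibition of growth than the free sulfanyl, including the 3,3,3-trifluoro-2-hydroxypropyl chain of compound 1. Nothing at hand accounts for the size of these steps.

Still open, on these data alone, is whether a methyl on the sulfur already gives much of this difference. Also open, as far as these compounds go, is how a chain ending in a carboxylic acid or an amine would compare.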